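The source may hold more compounds than are shown below. What is called first, only, known or untested is meant among the compounds shown, and "the series" means these compounds.

Measured compounds in hand:
compound 1 `CC(=O)OC/C(=C\c1ccccc1[N+](=O)[O-])C(=O)c1ccccc1`: 18000 nM
compound 2 `O=C(OC/C(=C\c1ccccc1[N+](=O)[O-])C(=O)c1ccccc1)c1ccccc1`: 4300 nM
compound 3 `CC(=O)OC/C(=C/c1ccc(Cl)cc1Cl)C(=O)c1ccccc1`: 22000 nM

All three values come from a functional assay on SW1573 cells (Homo sapiens) for inhibition, read by sulforhodamine B assay, with a stated time of 48 h; on this read-out lower numbers stand for stronger inhibition of growth and higher numbers for weaker inhibition of growth. Compound 1 and compound 2 share a core and differ only by phenyl in place of methyl on a carbonyl carbon; that change gave a 4.2-fold lower number from compound 1 to compound 2 (0.62 log units; beyond the scatter). Compound 3 carries a different core; the difference between the two cores is not broken down here, and the values of compound 3 and compound 1 lie within the usual scatter of each other, so no order between them is claimed.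

Compound 4 `O=C(OC/C(=C/c1ccc(Cl)cc1Cl)C(=O)c1ccccc1)c1ccccc1` is not yet measured. It differs from compound 3 by phenyl in place of methyl on a carbonyl carbon, the same change as from compound 1 to compound 2, with an identical place. Since the change occurs only twice among these compounds, the single measured step is the only guide. Given the step of a 4.2-fold lower number from compound 1 to compound 2 (0.62 log units; beyond the scatter), a step of similar size is expected here, a 4.0-fold lower number from compound 3 to compound 4 (0.60 log units; beyond the scatter), starting from the value of compound 3, 22000 nM. For compound 4 in this assay the estimate is 5500 nM, expected to fall between 2500 nM and 12000 nM.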

Compound 4, concentration for 50% growth inhibition: 29000 nM
Estimate against measurement, compound 4: 5.3-fold (0.72 log units) below, outside the stated range (above it).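

In this assay the change from acetoxy to benzoyloxy, phenyl in place of methyl on a carbonyl carbon, gave a 1.3-fold higher number from compound 3 to compound 4 (0.12 log units; within the scatter) on the core of compound 3, so the drop in the number seen on the core of compound 1 did not carry over. The two steps do not agree, and the change therefore cannot be transferred as a fixed increment between these two cores: the same change on two cores in this assay, a 4.2-fold lower number (0.62 log units; beyond the scatter) from compound 1 to compound 2 and a 1.3-fold higher number (0.12 log units; within the scatter) from compound 3 to compound 4, 5.5-fold (0.74 log units) apart, beyond the scatter of two such steps
This shows that the size of the step depends on the core in this pair of cores, but it does not show which difference between the cores is responsible, and one step per core gives no general rule for the series.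

Still open, from the compounds shown here alone, is how either core responds to other groups on the ester carbonyl, such as a longer chain in place of methyl, or to an amide or a carboxylic acid in place of the ester. A third core carrying both acetoxy and benzoyloxy would show whether either of the two steps is the more typical one.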